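From Fluoro to Cyano at the Limit of the Assay

The source may hold more compounds than are shown below. What is called first, only, known or untested is meant among the compounds shown, and "the series" means these compounds.

Measured so far in an ADME assay on MCF-10A cells (Homo sapiens) for inhibition, with a stated time of 48 h (on this read-out higher numbers stand for weaker inhibition and lower numbers for stronger inhibition), with each value a limit:
Compound 1 `O=C(Nc1ccc(Cl)cc1)N1CCC[C@H]1c1nc(-c2ccccc2F)no1` gives > 50000 nM as a limit
Compound 2 `Cc1ccc(-c2noc([C@@H]3CCCN3C(=O)Nc3ccc(Cl)cc3)n2)cc1` gives > 50000 nM as a limit
Compound 3 `O=C(Nc1ccc(Cl)cc1)N1CCC[C@H]1c1nc(-c2ccc(F)cc2)no1` gives > 50000 nM as a limit

Compound 3 gives > 50000 nM in this assay and this is a limit, not a number. The same holds for the whole set, which sits at the limit of > 50000 nM in this assay, at which 3 of the 3 values shown sit, without exception. The next compound, compound 4 `N#Cc1ccc(-c2noc([C@@H]3CCCN3C(=O)Nc3ccc(Cl)cc3)n2)cc1`, differs from compound 3 by cyano in place of fluoro on an aromatic carbon with cyano in place of fluoro on an aromatic carbon, para to a large group. Among the measured compounds shown here, three measured steps bear on this place in the molecule. They are a step that the two limits leave unreadable from compound 2 to compound 3 for fluoro in place of methyl, a step that the two limits leave unreadable from compound 1 to compound 3 for 4-fluorophenyl in place of 2-fluorophenyl, and a step that the two limits leave unreadable from compound 1 to compound 2 for 4-methylphenyl in place of 2-fluorophenyl on the same carbon framework. None of them offers a size to carry over. Since compound 3 sits at the limit of > 50000 nM in this assay, at which 3 of the 3 values shown sit, along with compound 1 and compound 2 , the expected change is a number no higher from compound 3 to compound 4 (the limit leaves the size open) with no direction and nothing beyond the scatter. For compound 4 the estimated value is 50000 nM with an expected range of 20000 nM to 100000 nM and a report as a limit is the likely outcome.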

Compound 4, half-maximal inhibitory concentration: > 50000 nM
Compound 4: a limit, no number (the forecaster's own chance of this, stated with the estimate: 85%); the middle value lies on the limit itself.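

No step can be read between compound 4 and compound 1, compound 2 or compound 3, as all four give a limit and not a number: the limit of > 50000 nM in this assay, at which 4 of the 4 values shown sit.

The compounds shown leave open whether any group at this place changes the inhibition, and what true value lies behind each limit.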